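Aminomethyl chromone series: piperidin-1-yl versus dimethylamino

A few compounds are considered here, and "the series" means these few. Any claim that something is new, unique, unknown or untested is made for them only; others in the source may bear on it.

Measured so far:
compound 1, `O=c1cc(-c2ccc([N+](=O)[O-])cc2)oc2c(CN3CCCCC3)cc(Cl)cc12`, in a functional assay on SMMC-7721 cells (Homo sapiens) for cytotoxicity, read by MTT assay, with a stated time of 48 h (on this read-out higher numbers stand for weaker inhibition and lower numbers for stronger inhibition), compound 1 gives 1090 nM
compound 2, `CN(C)Cc1cc(Cl)cc2c(=O)cc(-c3ccc([N+](=O)[O-])cc3)oc12`, compound 2 gives 56500 nM
compound 3, `O=c1cc(-c2ccccc2Cl)oc2c(CN3CCCCC3)cc(Cl)cc12`, compound 3 gives 3400 nM

Two changes have been made on the shared core. The first is dimethylamino in place of piperidin-1-yl on a saturated chain carbon bound to an aromatic carbon; it produced a 52-fold higher number from compound 1 to compound 2 (1.71 log units; beyond the scatter). The second is 2-chlorophenyl in place of 4-nitrophenyl on an aromatic carbon; it produced a 3.1-fold higher number from compound 1 to compound 3 (0.49 log units; beyond the scatter). Compound 3 thus stands with the second highest number of the three, with compound 1 nearer and compound 2 furthest from it.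

Compound 4, `CN(C)Cc1cc(Cl)cc2c(=O)cc(-c3ccccc3Cl)oc12`, has not been measured. It differs from compound 3 by dimethylamino in place of piperidin-1-yl on a saturated chain carbon bound to an aromatic carbon. This is the same change as the one made from compound 1 to compound 2, at the same place on the same kind of carbon, and the two pairs differ only in the group on the ring oxygen side of the core, which is the difference described above between compound 1 and compound 3.

Within the data shown here, the step from compound 3 to compound 4 in this assay is expected to be a 29-fold higher number from compound 3 to compound 4 (1.47 log units; beyond the scatter), because a 52-fold higher number from compound 1 to compound 2 (1.71 log units; beyond the scatter) is the only precedent for this change and was large. The expectation is held somewhat short of the earlier step since there is a single precedent and the rest of the molecule differs. Compound 4 is estimated at 100000 nM, with a range from 20000 nM to 400000 nM.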

Compound 4, half-maximal inhibitory concentration: 1140 nM
Compound 4: the middle estimate sits 88-fold (1.94 log units) above what was measured, and the stated range ends above it.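

In this assay, dimethylamino in place of piperidin-1-yl with 2-chlorophenyl on the aromatic carbon gives a 3.0-fold lower number from compound 3 to compound 4 (0.47 log units; beyond the scatter), the opposite direction to the step seen with 4-nitrophenyl there. Among these compounds, the change therefore does not carry from one core to the other, in size or in direction, and the precedent from the core of compound 1 cannot be used as a transferable increment: the same change on two cores in this assay, a 52-fold higher number (1.71 log units; beyond the scatter) from compound 1 to compound 2 and a 3.0-fold lower number (0.47 log units; beyond the scatter) from compound 3 to compound 4, 150-fold (2.19 log units) apart, beyond the scatter of two such steps This shows that the outcome of the amine change depends on the group at the other site, but with only one pair per core it does not show which feature of 4-nitrophenyl or 2-chlorophenyl is responsible, nor which of the opposing steps is closer to the usual behaviour of the change.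

Still open, on these data alone, is whether a third group on the aromatic carbon, such as unsubstituted phenyl or 4-methoxyphenyl, would follow the pair with 4-nitrophenyl, the pair with 2-chlorophenyl, or neither. Also open, as far as these compounds go, is how other amines on the saturated chain carbon, such as morpholin-4-yl, pyrrolidin-1-yl or diethylamino, would behave on each of the two cores.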